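This account rests on a few compounds, and the source may have more. Where it says the series, first, only, none or still open, it means among the compounds named here.

Compound 1 `NC(=O)c1ncn2c(=O)n(Cc3ccccc3)nnc12`, compound 2 `COc1cccc(Cn2nnc3c(C(N)=O)ncn3c2=O)c1` and compound 3 `C[C@H](c1ccccc1)n1nnc2c(C(N)=O)ncn2c1=O` have been tested in a functional assay on SNB-19 cells (Homo sapiens) for inhibition, read by MTT assay, with a stated time of 7 days; on this read-out lower numbers stand for stronger inhibition of growth and higher numbers for weaker inhibition of growth. In this assay compound 1 gives > 50000 nM, which is a limit of the assay and not a number. Compound 2 likewise gives > 50000 nM, again a limit. Among the compounds with values here, compound 3 gives 32700 nM, the only number among the three.

Compound 2 arises from compound 1 by methoxy in place of hydrogen on an aromatic carbon; the size of that step, a step that the two limits leave unreadable from compound 1 to compound 2, cannot be read because of the limit of > 50000 nM in this assay, at which 2 of the 3 values shown sit. Compound 3 differs from compound 1 by methyl in place of hydrogen on a saturated chain carbon bound to an aromatic carbon and an aromatic nitrogen, giving an at least 1.5-fold lower number from compound 1 to compound 3 (0.18 log units; that floor lies within the scatter).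

Compound 4 `COc1ccc([C@@H](C)n2nnc3c(C(N)=O)ncn3c2=O)cc1` has not yet been measured. It differs from compound 3 by methoxy in place of hydrogen on an aromatic carbon. Within the data shown here, this is the same kind of change as the one from compound 1 to compound 2, but not the same: there the methoxy sits meta to a large group, here para to a large group. With the earlier step that the two limits leave unreadable from compound 1 to compound 2 unreadable, the expected step of a 1.1-fold higher number from compound 3 to compound 4 (0.03 log units; within the scatter) rests only on the value of compound 3, 32700 nM, with the methoxy assumed to change little. Compound 4 is therefore estimated at 35000 nM, between 15000 nM and 80000 nM.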

Compound 4, concentration for 50% growth inhibition: > 50000 nM
Compound 4: a limit, no number; the forecaster's own chance of this, stated with the estimate: 40%; middle value at least 1.4-fold (0.15 log units) away from the limit.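

In this assay compound 4 gives > 50000 nM, which is a limit of the assay and not a number. Placing the methoxy on compound 3 gives an at least 1.5-fold higher number from compound 3 to compound 4 (0.18 log units; that floor lies within the scatter), and this is only a floor, so the true size of the step could be close to ordinary repeat variation or much larger. The earlier methoxy step cannot be read, and the new step has no readable size beyond its floor, so the data do not show whether this change has the same effect when carried from one compound pair to another: the limit of > 50000 nM in this assay, at which 3 of the 4 values shown sit.

Within the data shown here, compound 3, at 32700 nM, remains the only compound here with a number, so there is no readable measure of how methoxy shifts growth inhibition. From the compounds shown here alone, it also remains open what an amine or a carboxylic acid in place of the methoxy on the ring would do, or a longer chain in place of the methyl.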